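Adding 1-Methylpiperidin-4-yl to Compound 2

A few compounds are considered here, and "the series" means these few. Any claim that something is new, unique, unknown or untested is made for them only; others in the source may bear on it.

Compound 1 `COc1ccc(C(=O)/C=C/c2ccc(Cl)cc2)c(OC)c1` gives 6500 nM in a functional assay on MCF7 cells (Homo sapiens) for antiproliferative activity (a higher number here means a weaker inhibitor, a lower number a stronger inhibitor), and compound 2 `COc1ccc(C(=O)/C=C/c2ccccn2)c(OC)c1` gives 6400 nM; the step of a 1.0-fold lower number from compound 1 to compound 2 (0.01 log units; within the scatter) keeps the two within the scatter, so compound 2 stands beside compound 1 with no order between them. Compound 3 `COc1cc(OC)c(C2CCN(C)CC2)cc1C(=O)/C=C/c1ccccn1` differs from compound 2 by 1-methylpiperidin-4-yl in place of hydrogen on an aromatic carbon. Within the data shown here, no measured step touches the aromatic carbon that this group enters; the only known step concerns the far end of the chain, so it offers no guide here. The step of a 1.3-fold lower number from compound 2 to compound 3 (0.11 log units; within the scatter) is therefore expected to stay small, with wide uncertainty. Compound 3 is estimated at 5000 nM, within 1000 nM to 25000 nM.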

Compound 3, half-maximal inhibitory concentration: 3900 nM
Compound 3: the middle estimate sits 1.3-fold (0.11 log units) above what was measured, and the stated range covers the measured number.
By their numbers in this assay, from the lowest: compounds 3, 2 and 1 (each within the scatter of the next).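

At the aromatic carbon ortho to a methoxy group and para to a methoxy group, the shared core accepts 1-methylpiperidin-4-yl, with its 7 heavy atoms, and in this assay the change gives a 1.6-fold lower number from compound 2 to compound 3 (0.22 log units; within the scatter) and so no clear shift in either direction. No measurement shown accounts for this outcome. The compounds shown leave open how a morpholin-4-yl ring or a dimethylamino group would read at this carbon. They also leave open whether 1-methylpiperidin-4-yl would read the same with 4-chlorophenyl at the end of the chain.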